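This account rests on a few compounds, and the source may have more. Where it says the series, first, only, none or still open, it means among the compounds named here.

Measured so far:
compound 1, `O=C(N/N=C/c1cc(I)cc(I)c1O)c1ccc(Br)cc1`: in a functional assay on HepG2 cells (Homo sapiens) for cytotoxicity, with a stated time of 24 h (a higher number here means a weaker inhibitor, a lower number a stronger inhibitor), compound 1 gives 22300 nM.
compound 2, `O=C(N/N=C/c1cc(I)c(O)c(I)c1)c1ccc(O)cc1`: in this assay compound 2 gives 110000 nM.

Compound 2 stands at the highest of the two numbers obtained so far, and its nearest neighbour is compound 1, whose number is lower by a margin beyond the usual scatter. Compound 3, `O=C(N/N=C/c1cc(I)c(O)c(I)c1)c1ccc(I)cc1`, arises from compound 2 by iodo in place of hydroxy on an aromatic carbon. Going by the values given here, no pair of measured compounds isolates this change. Compound 1 does carry a bromo group in place of the hydroxy group that compound 3 replaces, but it also differs from compound 2 in the arrangement of its iodo groups, so its two values only show that compound 1 gives the lower number of the two. On that basis the expected step from compound 2 to compound 3 in this assay is a 3.1-fold lower number from compound 2 to compound 3 (0.50 log units; beyond the scatter), a moderate move toward a lower number, that is toward stronger inhibition, with considerable uncertainty. The value expected for compound 3 in this assay is therefore 35000 nM, within a range from 12000 nM to 100000 nM.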

Compound 3, half-maximal inhibitory concentration: > 50000 nM
Compound 3 ended at the assay's limit (the forecaster's own chance of this, stated with the estimate: 10%); middle value at least 1.4-fold (0.15 log units) from the limit.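

The result for compound 3 in this assay is a limit and not a number, so no step from compound 2 to compound 3 can be read, because the only value available for compound 3 is this limit: the limit of > 50000 nM in this assay, at which 1 of the 3 values shown sits.

The compounds shown leave open how large the effect of iodo in place of hydroxy on an aromatic carbon is, and in which direction it moves the number.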